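This account rests on a few compounds, and the source may have more. Where it says the series, first, only, none or still open, it means among the compounds named here.

Compound 1 `O=C(Nc1cccc(F)c1)C(Cl)Cl` gives "not determined" (no result reported) in a functional assay on Bel-7402 cells (Homo sapiens) for antiproliferative activity, read by MTT assay, with a stated time of 72 h; a higher number here means a weaker inhibitor, a lower number a stronger inhibitor. Compound 2 `O=C(Nc1cccc(Br)c1)C(Cl)Cl` gives 7720 nM in this assay. Compound 3 `N#Cc1cccc(NC(=O)C(Cl)Cl)c1` gives 48400 nM in this assay.

Among the two numbers in this assay, compound 3 stands at the higher end, the weaker inhibitor of the pair; the only measured step to it, a 6.3-fold higher number from compound 2 to compound 3 (0.80 log units; beyond the scatter), is the exchange of bromo for cyano on the same aromatic carbon of the shared core. Compound 4 `O=C(Nc1cccc([N+](=O)[O-])c1)C(Cl)Cl` follows from compound 3 by a further change at that carbon: nitro in place of cyano on an aromatic carbon. For the measured compounds named here, no measured pair shows a nitro entering or a cyano leaving, so the one step that bears on it only indirectly is the bromo-to-cyano step, which was modest. With nothing pointing either way, compound 3 is taken as the anchor and a step within or close to the scatter is expected, a 1.2-fold lower number from compound 3 to compound 4 (0.08 log units; within the scatter). Compound 4 is therefore expected to give about 40000 nM in this assay, with a range from 12000 nM to 130000 nM.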

Compound 4, half-maximal inhibitory concentration: 15700 nM
Estimate against measurement, compound 4: 2.5-fold (0.41 log units) above, within the range that was stated.
By their numbers in this assay, from the lowest: compound 2; then compound 4; then compound 3.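

Cyano and nitro do not stand alike at this aromatic carbon in this assay: the change gives a 3.1-fold lower number from compound 3 to compound 4 (0.49 log units; beyond the scatter), so the loss seen on going from bromo to cyano is not matched in full by every replacement of bromo. Nitro in place of bromo still gives a 2.0-fold higher number from compound 2 to compound 4 (0.31 log units; beyond the scatter), which leaves the three groups in the order bromo, nitro, cyano from the lowest number, each step lying beyond the scatter. Nothing at hand accounts for this order.

With compound 1 at "not determined" (no result reported), fluoro has no place in that order. The compounds shown also leave open where an amine, a carboxylic acid or a longer chain would stand at this carbon, and whether the order holds at any other carbon of the ring.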